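Dropping the drawn configuration of compound 3

The source may hold more compounds than are shown below. What is called first, only, known or untested is meant among the compounds shown, and "the series" means these compounds.

Three compounds built on the shared core were tested in a functional assay on the whole organism (strain Wistar) for inhibition, with Rattus norvegicus as the target, read by paw edema, with stated times of 1 h and 24 h, at a dose of 10 mg/kg by the intraperitoneal route; on this read-out higher numbers stand for more inhibition at the one dose given (going by the name of the read-out) and lower numbers for less inhibition. Compound 1 `COc1cc(/C=C/C(=O)/C=C(O)/C=C/c2ccc(OC(=O)[C@@H](CCSC)NC(=O)OCc3ccccc3)c(OC)c2)ccc1OC(=O)[C@@H](CCSC)NC(=O)OCc1ccccc1` gives 90%. Compound 2 `COc1cc(/C=C/C(=O)/C=C(O)/C=C/c2ccc(OC(=O)[C@H](C)NC(=O)OC(C)(C)C)c(OC)c2)ccc1OC(=O)[C@H](C)NC(=O)OC(C)(C)C` gives 5%. Compound 3 `COc1cc(/C=C/C(=O)/C=C(O)/C=C/c2ccc(OC(=O)[C@@H](C)NC(=O)OC(C)(C)C)c(OC)c2)ccc1OC(=O)[C@@H](C)NC(=O)OC(C)(C)C` gives 37%, the second highest of the three numbers. The change a number 32 percentage points higher from compound 2 to compound 3 (beyond the scatter) rests on (the fact that compounds 2 and 3 differ only in the configuration as drawn). Compound 4 `COc1cc(/C=C/C(=O)/C=C(O)/C=C/c2ccc(OC(=O)C(C)NC(=O)OC(C)(C)C)c(OC)c2)ccc1OC(=O)C(C)NC(=O)OC(C)(C)C` differs from compound 3 only in this way: the two compounds have the same atoms and bonds; at least one stereo element is drawn with a configuration in one of them and without one in the other: 2 of 5 stereo elements differ; a stereocentre at a saturated chain carbon is drawn R in compound 3 and without a configuration in compound 4; a stereocentre at a saturated chain carbon is drawn R in compound 3 and without a configuration in compound 4. Compound 4 therefore behaves like a mixture of the forms seen in compound 2 and compound 3, and its value is expected to fall between theirs, giving an expected change of a number 17 percentage points lower from compound 3 to compound 4 (beyond the scatter). Compound 4 is estimated at 20%, within 5% to 40%.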

Compound 4, a percentage reported as inhibition, in the whole organism at one dose (the size of the read-out at that dose, not a potency): 29%
Beside the measured number, compound 4's estimate is 9 percentage points below it; low and high end bracket the measured number.
By their numbers in this assay, from the lowest: compound 2; then compounds 4 and 3 (each within the scatter of the next); then compound 1.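

The form drawn without a configuration gives a number 8 percentage points lower from compound 3 to compound 4 (within the scatter), while it also gives a number 24 percentage points higher from compound 2 to compound 4 (beyond the scatter). At these two stereocentres, then, compound 4 cannot be told apart from the R form, yet it stands clearly apart from the S form. Compound 2 alone carries the S drawing, so this low number belongs to that form, not to a loss of drawn configuration as such.

The drawing of compound 4 does not give the share of each form it holds. Going by these compounds, whether configuration matters as much with a free amine in place of the carbamate remains open.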